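Swapping But-1-en-1-yl for 2-Methylprop-1-en-1-yl on the Amide

A few compounds are considered here, and "the series" means these few. Any claim that something is new, unique, unknown or untested is made for them only; others in the source may bear on it.

Among the measured compounds shown here, in a functional assay on MCF7 cells (Homo sapiens) for antiproliferative activity, read by MTT assay, with a stated time of 72 h (a higher number here means a weaker inhibitor, a lower number a stronger inhibitor), compound 1 (`C/C=C/C(=O)Nc1cccc(Oc2nc(Nc3ccc(OC)cc3)nc3c2CSCC3)c1`) gives 24300 nM and compound 2 (`CC/C=C/C(=O)Nc1cccc(Oc2nc(Nc3ccc(OC)cc3)nc3c2CSCC3)c1`) gives 31400 nM as the only numbers so far. These two values lie within the scatter of each other, so compound 2 stands together with compound 1 and no order can be claimed. Compound 3 (`COc1ccc(Nc2nc3c(c(Oc4cccc(NC(=O)C=C(C)C)c4)n2)CSCC3)cc1`) holds the same atoms as compound 2, joined differently (2-methylprop-1-en-1-yl in place of but-1-en-1-yl on a carbonyl carbon), with 2-methylprop-1-en-1-yl in place of but-1-en-1-yl on a carbonyl carbon. For the measured compounds named here, the one measured step that bears on this is the chain change (a 1.3-fold higher number from compound 1 to compound 2 (0.11 log units; within the scatter)), and no measured compound yet carries the entering group. A step beyond the scatter is therefore not expected in this assay, and the estimated change is small (a 1.1-fold lower number from compound 2 to compound 3 (0.05 log units; within the scatter)) in either direction. Compound 3 is expected at 28000 nM (with an estimated range from 12000 nM to 60000 nM).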

Compound 3, half-maximal inhibitory concentration: > 50000 nM
Compound 3 was reported as a limit (the forecaster's own chance of this, stated with the estimate: 15%); at least 1.7-fold (0.25 log units) between middle value and limit.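

In this assay, among the compounds shown here, compound 3 stands only as a limit, > 50000 nM, the one such entry among the values shown: the limit of > 50000 nM in this assay, at which 1 of the 3 values shown sits. The 2-methylprop-1-en-1-yl group on the carbonyl carbon gives the first step at this position to pass the scatter, with an at least 2.0-fold higher number from compound 1 to compound 3 (0.31 log units; beyond the scatter). Set against but-1-en-1-yl, its isomeric partner with the same atoms, the same group gives an at least 1.5-fold higher number from compound 2 to compound 3 (0.20 log units; that floor lies within the scatter), so this comparison rests on a floor alone and the two compounds cannot be put in order.

From the compounds shown here alone, the true value of compound 3 remains open, as does whether any group on this carbonyl carbon can give a lower number than compound 1 and compound 2 do. Going by these compounds, how a phenyl group or a chain ending in an amine would read in this assay is also open.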